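Swapping fluoro for bromo: what the cell assay may show

The source may hold more compounds than are shown below. What is called first, only, known or untested is meant among the compounds shown, and "the series" means these compounds.

Measured so far:
- compound 1 `O=C(N/N=C/c1cccc(F)c1)c1cnccn1` gives 40%
- compound 2 `O=C(N/N=C/c1ccc(F)cc1)c1cnccn1` gives 71%
- compound 3 `O=C(N/N=C/c1cccc(Br)c1)c1cnccn1` gives 93%

These three compounds were tested in an ADME assay on J774 cells (Mus musculus) for cytotoxicity, read by MTT assay, with a stated time of 48 h, tested at 150 ug/mL; a lower number here means a stronger effect, a higher number a weaker effect of the compound at the concentration tested. Compound 1 and compound 3 share one core and differ by a single change, (bromo in place of fluoro on an aromatic carbon); this change made a step of a number 53 percentage points higher from compound 1 to compound 3 (beyond the scatter). Compound 2 is built from the same atoms as compound 1, but joined differently; the difference between the two cores is not broken down here. Compound 2 stands between the other two in this assay.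

Compound 4 `O=C(N/N=C/c1ccc(Br)cc1)c1cnccn1` has not yet been measured. It differs from compound 2 by bromo in place of fluoro on an aromatic carbon. Among the measured compounds shown here, this is the same kind of change as the one from compound 1 to compound 3, but the place is not identical: there the bromo sits meta to a large group, here it sits para to a large group. Because the earlier step was a number 53 percentage points higher from compound 1 to compound 3 (beyond the scatter), a step of similar direction is expected from compound 2 to compound 4, though the read-out cannot rise far above the top of its scale; the expected step is a number 22 percentage points higher from compound 2 to compound 4 (beyond the scatter). Compound 4 is therefore estimated at 93%, between 78% and 100%.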

Compound 4, a percentage reported as activity, at one concentration (the size of the read-out at that concentration, not a potency): 94%
Compound 4: the middle estimate sits 1 percentage points below what was measured; the measured number falls inside the stated range.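

In this assay, where a higher number means a weaker effect, putting bromo in place of fluoro on the second core gave a number 23 percentage points higher from compound 2 to compound 4 (beyond the scatter), so the direction of the change held on both cores shown. The size of the step, however, did not carry over from one core to the other: the same change on two cores in this assay, a number 53 percentage points higher (beyond the scatter) from compound 1 to compound 3 and a number 23 percentage points higher (beyond the scatter) from compound 2 to compound 4, 30 percentage points apart, beyond the scatter of two such steps. Two pairs of compounds are too few to give a rule for other cores, they do not show what sets the size of the step, and a reading at one concentration says nothing about potency.

The compounds shown carry only fluoro or bromo on the aromatic ring, so it stays open where chloro, an amine or a carboxylic acid in the same place would fall in this assay. Also open, going by these compounds, is whether the same swap on a core beyond these two would again give a higher number, and by how much.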